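The source may report more compounds than this note shows. Statements on the series, on what has been measured and on what is new or still open speak of the compounds shown alone.

In an ADME assay on the whole organism (plasma) for pharmacokinetics, with Homo sapiens as the target (a higher number here means that the compound lasts longer, a lower number that the compound disappears faster), compound 1 `CCCCCCCCCCCCCCCCOP(=O)(O)OCC1C=CC(n2cc(C)c(=O)[nH]c2=O)O1` gives > 24 h, which is a limit and not a number. Compound 2 `Cc1cn(C2C=CC(COP(=O)(O)OCC3C=CC(n4cc(C)c(=O)[nH]c4=O)O3)O2)c(=O)[nH]c1=O` gives > 24 h, also a limit and not a number. Compound 2 therefore stands at the limit of > 24 h in this assay, at which 2 of the 2 values shown sit, with no exact half-life to build on. Compound 3 `Cc1cn(C2C=CC(COP(=O)(OCCC#N)OCC3C=CC(n4cc(C)c(=O)[nH]c4=O)O3)O2)c(=O)[nH]c1=O` carries 2-cyanoethyl in place of hydrogen on an oxygen, a change counted as 2-cyanoethyl in place of hydrogen on an oxygen. Within the data shown here, no measured pair shows this change, so the forecast in this assay is a judgement: a shorter half-life, by more than the scatter. The expected step is an at least 2.4-fold lower number from compound 2 to compound 3 (0.38 log units; beyond the scatter). For compound 3 the estimate is 10 h, with an expected range of 3 h to 30 h.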

Compound 3, half-life: 12 h
For compound 3 the middle estimate is 1.2-fold (0.08 log units) below the measured one, within the range that was stated.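

In this assay, among these compounds, placing 2-cyanoethyl on an oxygen whose other neighbours are phosphorus gives the first readable step at this position: an at least 2.0-fold lower number from compound 2 to compound 3 (0.30 log units; that floor lies within the scatter). Compound 3 also gives the first half-life here that is a number rather than a limit. Compound 2 sits at a limit, so the step has only a floor, and the true change could be larger: the limit of > 24 h in this assay, at which 2 of the 3 values shown sit.

On these data alone, it remains open whether the nitrile of 2-cyanoethyl matters, or whether a plain ethyl group would give a similar half-life. As far as these compounds go, how a longer chain or an amine-bearing chain on this oxygen would behave also stays unknown.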